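Swapping the hydroxy for a chloro on compound 3's phenyl ring

The source may report more compounds than this note shows. Statements on the series, on what has been measured and on what is new or still open speak of the compounds shown alone.

Of the compounds shown here, three sharing one core have been measured in a functional assay on CHO cells for antagonist activity at adenosine receptor A2b (Homo sapiens), read by 33P incorporation, with a stated time of 20 min; a lower number here means a stronger inhibitor, a higher number a weaker inhibitor. Compound 1 `CCn1c(-c2ccccc2)nc2c(NC3CCC3)ncnc21` gives 1440 nM. Among the measured compounds shown here, compound 2 `CCCn1c(-c2ccccc2)nc2c(NC3CCC3)ncnc21` gives 774 nM; the step of a 1.9-fold lower number from compound 1 to compound 2 (0.27 log units; within the scatter) is the only single-point comparison available. Compound 3 `Cn1c(-c2ccc(O)cc2)nc2c(NC3CCCC3)ncnc21` gives 17800 nM, the highest number of the three and the least potent compound, beyond the scatter from both others.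

Compound 4 `Cn1c(-c2ccc(Cl)cc2)nc2c(NC3CCCC3)ncnc21` differs from compound 3 by chloro in place of hydroxy on an aromatic carbon: in words, chloro in place of hydroxy on an aromatic carbon, para to a large group. For the measured compounds named here, no measured step touches this position; the one measured step concerns a saturated chain and is within the scatter, so it offers no guide. Going by the values given here, the only bearing is that compounds 1 and 2, which carry no hydroxy on that ring, sit well below compound 3. Compound 4 is therefore expected to move downward, with the estimated step of a 3.6-fold lower number from compound 3 to compound 4 (0.55 log units; beyond the scatter). The value expected for compound 4 in this assay is 5000 nM, within a range from 1500 nM to 18000 nM.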

Compound 4, inhibition constant: > 30000 nM
Compound 4 ended at the assay's limit (the forecaster's own chance of this, stated with the estimate: 5%); middle value at least 6.0-fold (0.77 log units) away from the limit.
By their numbers in this assay, from the lowest: compounds 2 and 1 (each within the scatter of the next); then compound 3. At a limit, above all of these: compound 4.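

Compound 4 stands at a limit in this assay, not at a number: the limit of > 30000 nM in this assay, at which 1 of the 4 values shown sits. As far as these compounds go, the step reads an at least 1.6-fold higher number from compound 3 to compound 4 (0.22 log units; that floor lies within the scatter), and because it is only a floor, its true size stays unknown. Among the compounds shown here, it is still the first reading at this aromatic carbon, para to a large group, and it shows that going from 4-hydroxyphenyl to 4-chlorophenyl brings no lower number, so losing the hydroxy does not by itself help here.

From the compounds shown here alone, how far compound 4 lies past the limit remains open, as does where a plain phenyl would fall on the core of compound 3, since compounds 1 and 2 differ from it in more than one place. Also open, going by these compounds, is how a methoxy, a fluoro or an amine would read at this same carbon.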